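Amide amine swap in the chloro-benzoxazole-free series: compound 4

The source may report more compounds than this note shows. Statements on the series, on what has been measured and on what is new or still open speak of the compounds shown alone.

Working notes on the series built around the shared core of compound 2 `O=C(CCSc1nc2cc(Cl)ccc2o1)N1CCCCC1`. For the measured compounds named here, in an ADME assay on microsomes from liver (Mus musculus) for metabolic stability, read by LC-MS, using NADPH, with a stated time of 45 min, tested at 0.5 uM (a higher number here means faster removal of the compound, a lower number slower removal), compound 2 gives 128 mL/min/g, the highest of the three numbers measured so far. Compound 1 `O=C(CCNc1nc2cc(Cl)ccc2o1)N1CCCC1` stands nearest; in this assay compound 1 gives 81.1 mL/min/g, within the scatter of compound 2, so no order between them can be read. Compound 3 `CS(=O)(=O)C1CCN(C(=O)CCSc2nc3cc(Cl)ccc3o2)CC1` stands furthest; in this assay compound 3 gives 2.6 mL/min/g. Going by the values given here, the one step measured in a single place is a 49-fold lower number from compound 2 to compound 3 (1.69 log units; beyond the scatter).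

Compound 4 `CN(C)C(=O)CCSc1nc2cc(Cl)ccc2o1` is the next member. It differs from compound 2 by dimethylamino in place of piperidin-1-yl on a carbonyl carbon. Among the compounds with values here, no measured step touches the amine part of the amide: the only step on record, from compound 2 to compound 3, alters a saturated ring carbon of the piperidin-1-yl group and is large, but it does not tell what removing that ring and putting dimethylamino in its place does. The values of compound 1 and compound 2, which carry different saturated amide rings and also different linkers, sit within the scatter of one another, which gives no ground for a directional change. The expected step is therefore a 1.3-fold lower number from compound 2 to compound 4 (0.11 log units; within the scatter), no further than the scatter. For compound 4 in this assay the estimate is 100 mL/min/g, with a range from 45 mL/min/g to 220 mL/min/g.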

Compound 4, intrinsic clearance in a liver preparation (reported as CLH), per the amount of preparation that the assay uses: 41.8 mL/min/g
The estimate for compound 4 lay 2.4-fold (0.38 log units) above the measured number; measured number below the stated range.
By their numbers in this assay, from the lowest: compound 3; then compounds 4, 1 and 2 (each within the scatter of the next, the first and the last beyond it).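

In this assay, the amine part of the amide now has a measured step of its own: a 3.1-fold lower number from compound 2 to compound 4 (0.49 log units; beyond the scatter). The exchange of the whole piperidin-1-yl group on the carbonyl carbon therefore moves the number beyond the scatter, whereas the record previously held only a substitution on a saturated carbon of that ring. This modest step stands beside the large 49-fold lower number from compound 2 to compound 3 (1.69 log units; beyond the scatter), which keeps the ring and adds methylsulfonyl, so of the two changes made to the amine part of compound 2, the ring substitution gives the larger drop, and no measurement shown here gives a reason for either.

Dimethylamino differs from piperidin-1-yl both in lacking a ring and in its smaller count of heavy atoms, and the compounds shown cannot separate these two differences. As far as these compounds go, open-chain diethylamino and small-ring azetidin-1-yl on the same carbonyl carbon would bear on that question, and it also remains open whether morpholin-4-yl, with a ring oxygen, would follow compound 2 or compound 3.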